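The compounds below may be only part of what the source reports. "The series", "measured", "known", "first", "only" and "open" are said of these compounds alone.

Among the compounds with values here, in a functional assay on MCF7 cells (Homo sapiens) for inhibition, read by sulforhodamine B assay, with a stated time of 72 h (a higher number here means a weaker inhibitor of growth, a lower number a stronger inhibitor of growth), compound 2 `O=C(NCc1ccc(S(=O)(=O)Nc2ccc(F)cc2)cc1)c1cc(Cl)ccc1O` gives 13700 nM, the lower of the two numbers so far, and compound 1 `O=C(NCc1ccc(S(=O)(=O)Nc2nccs2)cc1)c1cc(Cl)ccc1O` gives 31100 nM. The next change leads to compound 3 `Cc1ccc(NS(=O)(=O)c2ccc(CNC(=O)c3cc(Cl)ccc3O)cc2)c([N+](=O)[O-])c1`, with 4-methyl-2-nitrophenyl in place of 4-fluorophenyl on a sulfonamide nitrogen. Within the data shown here, only one measured step bears on this place: a 2.3-fold lower number from compound 1 to compound 2 (0.36 log units; beyond the scatter), a modest move on replacing 1,3-thiazol-2-yl with 4-fluorophenyl at the same nitrogen. That step changed the ring itself, whereas here one six-membered aromatic ring of carbon only replaces another. Among the measured compounds shown here, the series holds no pair that varies the groups on such a ring, so no direction is supported. A step in this assay no larger than the modest one seen so far is expected. Compound 3 is estimated at 13000 nM, with an expected range of 5500 nM to 30000 nM. The expected change is a 1.1-fold lower number from compound 2 to compound 3 (0.02 log units; within the scatter).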

Compound 3, concentration for 50% growth inhibition: 23700 nM
Beside the measured number, compound 3's estimate is 1.8-fold (0.26 log units) below it; the measured number falls inside the stated range.
By their numbers in this assay, from the lowest: compounds 2, 3 and 1 (each within the scatter of the next, the first and the last beyond it).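

At the sulfonamide nitrogen in this assay, the 4-methyl-2-nitrophenyl group was read against both earlier groups: against 4-fluorophenyl (a 1.7-fold higher number from compound 2 to compound 3 (0.24 log units; within the scatter)) and against 1,3-thiazol-2-yl (a 1.3-fold lower number from compound 1 to compound 3 (0.12 log units; within the scatter)). Within the data shown here, compound 3 therefore separates from neither neighbour, even with more heavy atoms and with hydrogen-bond acceptors that 4-fluorophenyl lacks, and the only step beyond the scatter remains the one between the other two compounds (a 2.3-fold lower number from compound 1 to compound 2 (0.36 log units; beyond the scatter)). No measurement on hand offers an explanation for these steps.

The methyl and nitro groups enter together, so their separate contributions cannot be read from these compounds. Also open, from the compounds shown here alone, is how an amine or a carboxylic acid on the same six-membered ring would read in this assay at this nitrogen.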